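Swapping the ring-nitrogen substituent in a Toll-like receptor 8 agonist series

This account rests on a few compounds, and the source may have more. Where it says the series, first, only, none or still open, it means among the compounds named here.

Measured compounds:
compound 1 `CCCCNc1nc(N)nc2c1CCN(Cc1ccccc1)C2`, 0.4 uM
compound 2 `CCCCNc1nc(N)nc2c1CN(S(C)(=O)=O)CC2`, 9.9 uM

Both were tested in an assay on HEK293 cells for agonist activity at Toll-like receptor 8 (Homo sapiens), read by a luciferase reporter, with a stated time of 6 h; a higher number here means that more compound is needed for the effect, a lower number that less compound is needed. Compound 2 stands at the higher of the two numbers; in this assay compound 2 gives 9.9 uM, while compound 1 gives 0.4 uM, a gap well beyond the scatter. Among the compounds with values here, these two compounds differ in more than one place, so no single step between them is defined; only their two values can be compared.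

Compound 3 `CCCCNc1nc(N)nc2c1CN(Cc1ccncc1)CC2` is the compound not yet measured. It differs from compound 2 in one place: (pyridin-4-yl)methyl in place of methylsulfonyl on an amine nitrogen in a ring. The new group carries an aromatic ring on the same ring nitrogen, a feature shared in spirit with compound 1 rather than with compound 2.

The expectation is that the step from compound 2 to compound 3 in this assay is a decrease of a 12-fold lower number from compound 2 to compound 3 (1.09 log units; beyond the scatter), that is, less compound is expected to be needed. This estimate rests on compound 1, which in this assay gives 0.4 uM with an aromatic-bearing group at that nitrogen. Compound 3 is therefore estimated at 0.8 uM, with a range from 0.2 uM to 4 uM.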

Compound 3, minimum effective concentration: 0.29 uM
Compound 3: middle estimate off by 2.8-fold (0.44 log units), on the high side, and the stated range covers the measured number.
By their numbers in this assay, from the lowest: compounds 3 and 1 (each within the scatter of the next); then compound 2.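

The ring nitrogen turns out to be a place where the choice of substituent matters greatly: in this assay, (pyridin-4-yl)methyl in place of methylsulfonyl gives a 34-fold lower number from compound 2 to compound 3 (1.53 log units; beyond the scatter) with the rest of the molecule unchanged. The gap between the two earlier compounds could not be tied to any single place, since they differ in more than one, whereas this step ties a large change to the group on this amine nitrogen in a ring. Nothing available here explains why this swap has so large an effect.

This one step removes a methylsulfonyl group and brings in a (pyridin-4-yl)methyl group at the same time, so it cannot say whether losing the first or gaining the second accounts for the change, or whether the nitrogen in the aromatic ring plays any part. On the same core, a plain benzyl group, a (pyridin-3-yl)methyl group, an acetyl group or a simple butyl chain on this nitrogen would help to separate these possibilities.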